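The source may hold more compounds than are shown below. What is called first, only, known or untested is meant among the compounds shown, and "the series" means these compounds.

Measured so far in a functional assay for inhibition of nuclear factor NF-kappa-B complex (Homo sapiens); a lower number here means a stronger inhibitor, a higher number a weaker inhibitor:
compound 1, `CCCC(=O)C1=Cc2ccc(OC)cc2OC1c1cc(OC)c(OC)c(OC)c1` — 11700 nM
compound 2, `COc1ccc2c(c1)OC(c1cc(OC)c(OC)c(OC)c1)C(C(N)=O)=C2` — > 50000 nM
compound 3, `COc1ccc2c(c1)OC(c1cc(OC)c(OC)c(OC)c1)C(C#N)=C2` — 3400 nM

The value of compound 2 in this assay is a limit of the assay, not a number, as recorded under (the limit of > 50000 nM in this assay, at which 1 of the 3 values shown sits). Compound 2 thus carries the highest number of the three: the step of an at least 4.2-fold higher number from compound 1 to compound 2 (0.63 log units; beyond the scatter) and the step of an at least 14-fold lower number from compound 2 to compound 3 (1.16 log units; beyond the scatter) are both beyond the scatter, and the latter is the largest movement in the set.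

Compound 4, `COC(=O)C1=Cc2ccc(OC)cc2OC1c1cc(OC)c(OC)c(OC)c1`, differs from compound 2 by methoxy in place of amino on a carbonyl carbon. Among the measured compounds shown here, two measured steps bear on this change, both at the carbonyl carbon or its ring carbon: an at least 4.2-fold higher number from compound 1 to compound 2 (0.63 log units; beyond the scatter) and an at least 14-fold lower number from compound 2 to compound 3 (1.16 log units; beyond the scatter). Replacing the amino group moved the number downward in each case. For methoxy in place of amino a downward step is therefore expected, the step from compound 2 to compound 4 being estimated at an at least 3.3-fold lower number from compound 2 to compound 4 (0.52 log units; beyond the scatter), smaller than the move to compound 3. The expected value for compound 4 in this assay is 15000 nM, with a range of 5000 nM to 50000 nM.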

Compound 4, half-maximal inhibitory concentration: 13800 nM
The estimate for compound 4 lay 1.1-fold (0.04 log units) above the measured number; low and high end bracket the measured number.
By their numbers in this assay, from the lowest: compound 3; then compounds 1 and 4 (each within the scatter of the next). At a limit, above all of these: compound 2.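

In this assay, methoxy and propyl on the carbonyl carbon cannot be told apart: a 1.2-fold higher number from compound 1 to compound 4 (0.07 log units; within the scatter). Of the three groups shown on that carbonyl carbon, only amino gives a limit rather than a number, so methoxy in place of amino can be read only as a bound, an at least 3.6-fold lower number from compound 2 to compound 4 (0.55 log units; beyond the scatter), and the value for compound 2 is a limit: the limit of > 50000 nM in this assay, at which 1 of the 4 values shown sits. The cyano group keeps its place as the best replacement shown for the group on the double-bonded ring carbon, a 4.1-fold higher number from compound 3 to compound 4 (0.61 log units; beyond the scatter), so the methoxycarbonyl group does not match it.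

On these data alone, whether the amide hydrogen matters remains open, and a dimethylamide on the same carbon would address that. The compounds shown also leave open how a carboxylic acid or a longer ester chain would compare at this position.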